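Fluoro in Place of Bromo: What to Expect for Compound 4

The source may report more compounds than this note shows. Statements on the series, on what has been measured and on what is new or still open speak of the compounds shown alone.

Compound 1: `Cc1ccc(OCC(=O)NNC(=O)c2cc3ccccc3oc2=O)c(C(=O)c2ccccc2)c1` — 86400 nM
Compound 2: `Cc1ccc(OCC(=O)NNC(=O)c2cc3ccccc3oc2=O)c(C(=O)c2ccccc2Cl)c1` — 53800 nM
Compound 3: `Cc1ccc(OCC(=O)NNC(=O)c2cc3ccccc3oc2=O)c(C(=O)c2ccc(Br)cc2)c1` — 92200 nM

All three compounds were tested in a functional assay on DLA cells (Mus musculus) for cytotoxicity, read by MTT assay, with a stated time of 48 h; on this read-out higher numbers stand for weaker inhibition and lower numbers for stronger inhibition. Compound 3 carries the largest number of the three as it reads, but the step of a 1.1-fold higher number from compound 1 to compound 3 (0.03 log units; within the scatter) and the step of a 1.7-fold higher number from compound 2 to compound 3 (0.23 log units; within the scatter) both sit within the scatter, so no order among compounds 1, 2 and 3 can be claimed from these numbers.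

Compound 4, `Cc1ccc(OCC(=O)NNC(=O)c2cc3ccccc3oc2=O)c(C(=O)c2ccc(F)cc2)c1`, differs from compound 3 in one place: fluoro in place of bromo on an aromatic carbon. Among the measured compounds shown here, two measured steps bear on this change. Putting a halogen onto the same ring of the shared core gave a 1.1-fold higher number from compound 1 to compound 3 (0.03 log units; within the scatter) and a 1.6-fold lower number from compound 1 to compound 2 (0.21 log units; within the scatter), and exchanging one halogenated ring for another gave a 1.7-fold higher number from compound 2 to compound 3 (0.23 log units; within the scatter); none of these moved the number beyond the scatter. Exchanging bromo for fluoro at this place is therefore expected to produce no step beyond the scatter in this assay, and the estimated step is a 1.1-fold lower number from compound 3 to compound 4 (0.04 log units; within the scatter).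

On that basis compound 4 is expected to give about 85000 nM in this assay, with a range from 40000 nM to 180000 nM.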

Compound 4, half-maximal inhibitory concentration: 43400 nM
Beside the measured number, compound 4's estimate is 2.0-fold (0.29 log units) above it; low and high end bracket the measured number.
By their numbers in this assay, from the lowest: compounds 4, 2, 1 and 3 (each within the scatter of the next, the first and the last beyond it).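

In this assay, fluoro in place of bromo on the aromatic carbon para to a large group gave a 2.1-fold lower number from compound 3 to compound 4 (0.33 log units; beyond the scatter) and is the only step among these four compounds that lies beyond the scatter, so at this place the choice of halogen can shift the number, if only modestly. That step stands alone, since fluoro in place of hydrogen gave a 2.0-fold lower number from compound 1 to compound 4 (0.30 log units; within the scatter) and 4-fluorophenyl in place of 2-chlorophenyl gave a 1.2-fold lower number from compound 2 to compound 4 (0.09 log units; within the scatter), both within the scatter, which separates compound 4 from compound 3 but not from compound 1 or compound 2. No measurement shown here bears on why fluoro and bromo differ at this place.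

As far as these compounds go, it remains open whether chloro, an amine or a carboxylic acid at this same place would read with fluoro, with bromo or apart from both. Also open, from the compounds shown here alone, is whether the exchange of bromo for fluoro would give a step of similar size on another part of the shared core.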